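The compounds below may be only part of what the source reports. "The series", "measured", "known", "first", "only" and "open" are said of these compounds alone.

Measured in a physicochemical assay for lipophilicity, using the shake flask method, at pH 7.4; on this read-out lower numbers stand for lower lipophilicity and higher numbers for higher lipophilicity:
Compound 1 `CCCC(Oc1ccc(-n2cc(OC)cn2)cc1)c1ccc(C(=O)NCCC(=O)O)cc1`: 1.4
Compound 2 `O=C(O)CCNC(=O)c1ccc(C(Oc2ccc(-n3cc(C(F)(F)F)cn3)cc2)C2CCC2)cc1`: 2.6

Compound 1 stands lowest of the two at 1.4, and compound 2 lies higher at 2.6, a gap beyond the scatter. Compound 3 `CCCC(Oc1ccc(-n2cc(C#N)cn2)cc1)c1ccc(C(=O)NCCC(=O)O)cc1` keeps the rest of compound 1 and carries cyano in place of methoxy on an aromatic carbon. Within the data shown here, no measured pair shows this change alone, so the expectation starts from compound 1 at 1.4. In this assay, the estimated change is a number 0.10 log units lower from compound 1 to compound 3 (within the scatter), a slight fall expected to stay within the scatter. Compound 3 is expected at 1.3, within an estimated range of 0.9 to 1.7.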

Compound 3, distribution coefficient: 1.2
Beside the measured number, compound 3's estimate is 0.10 log units above it; low and high end bracket the measured number.
By their numbers in this assay, from the lowest: compounds 3 and 1 (each within the scatter of the next); then compound 2.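

Exchanging 4-methoxy-1H-pyrazol-1-yl for 4-cyano-1H-pyrazol-1-yl gives, in this assay, a number 0.20 log units lower from compound 1 to compound 3 (within the scatter). Among these compounds, this is the first step that isolates one place, and on this read-out the two groups at this aromatic carbon cannot be told apart, whereas compound 1 and compound 2 differ in more than one place. No evidence on the reason for this result is available. As far as these compounds go, it remains open whether an amine or a chlorine atom at this carbon would also stay within the scatter of compound 1, and what trifluoromethyl would do there without any other change.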